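This account rests on a few compounds, and the source may have more. Where it says the series, first, only, none or still open, it means among the compounds named here.

Compound 1 `Cn1c(/C=C2\SC(=O)N(CC(=O)Nc3nc(-c4ccccc4)cs3)C2=O)nc2ccccc21` was tested in a functional assay on A549 cells (Homo sapiens) for inhibition, read by MTT assay, with a stated time of 48 h (a higher number here means a weaker inhibitor, a lower number a stronger inhibitor), where compound 1 gives 11500 nM. Compound 2 `CCn1c(/C=C2\SC(=O)N(CC(=O)N3CCc4cc(OC)c(OC)cc4C3)C2=O)nc2ccccc21` belongs to a different core, and the difference between the two cores is not broken down here; in this assay compound 2 gives 26200 nM, the higher number of the two measured compounds. Compound 3 `CCn1c(/C=C2\SC(=O)N(CC(=O)Nc3nc(-c4ccccc4)cs3)C2=O)nc2ccccc21` in this assay reaches only a limit, > 50000 nM, which is not a number. The change from compound 1 to compound 3 is methyl in place of hydrogen on a saturated chain carbon bound to an aromatic nitrogen, and it brought an at least 4.3-fold higher number from compound 1 to compound 3 (0.63 log units; beyond the scatter), a size that rests on (the limit of > 50000 nM in this assay, at which 1 of the 3 values shown sits).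

Compound 4 `COc1cc2c(cc1OC)CN(C(=O)CN1C(=O)S/C(=C\c3nc4ccccc4n3C(C)C)C1=O)CC2` has not been measured. It differs from compound 2 by methyl in place of hydrogen on a saturated chain carbon bound to an aromatic nitrogen and a saturated chain carbon, the same kind of change, though here the carbon is also bound to a saturated chain carbon. Given that the earlier step of an at least 4.3-fold higher number from compound 1 to compound 3 (0.63 log units; beyond the scatter) already weakened inhibition, compound 4 is expected to be weaker than compound 2 by a 2.7-fold higher number from compound 2 to compound 4 (0.43 log units; beyond the scatter). The estimate for compound 4 in this assay is 70000 nM, with a plausible range from 30000 nM to 200000 nM, and it may well be reported only as a limit.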

Compound 4, half-maximal inhibitory concentration: 20600 nM
The estimate for compound 4 lay 3.4-fold (0.53 log units) above the measured number, and the stated range ends above it.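

In this assay, the added methyl brought a 1.3-fold lower number from compound 2 to compound 4 (0.10 log units; within the scatter), so on the core of compound 2 the change from ethyl to isopropyl had no effect that can be told from the scatter. Set beside the earlier step, the addition of a methyl at the carbon on the aromatic nitrogen did not carry over from one core to the other: the same change on two cores in this assay, an at least 4.3-fold higher number (0.63 log units; beyond the scatter) from compound 1 to compound 3 and a 1.3-fold lower number (0.10 log units; within the scatter) from compound 2 to compound 4, at least 5.5-fold (0.74 log units) apart, beyond the scatter of two such steps This does not show that the core alone sets the outcome, as the carbon taking the methyl is also bound to a saturated chain carbon only in the later step, and the step to compound 3 ends in a limit rather than a number: the limit of > 50000 nM in this assay, at which 1 of the 4 values shown sits.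

The compounds shown leave open how an isopropyl group on the core of compound 1, or a methyl group on the core of compound 2, would compare. They also leave open how a longer chain such as n-propyl, or a cyclopropyl ring, on the same aromatic nitrogen would read on either core.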